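The compounds below may be only part of what the source reports. "The series", "measured", "known", "first", "only" and "open" are said of these compounds alone.

Compound 1 `COc1cc(C(=O)O)ccc1OCCCCOc1ccc(C(=O)C(C)C)c(O)c1C` gives 113 nM in an assay on HEK293 cells for positive allosteric modulation of metabotropic glutamate receptor 2 (Rattus norvegicus), read by thallium flux, with a stated time of 2.5 min; on this read-out lower numbers stand for an effect already at smaller amounts and higher numbers for an effect only at larger amounts of compound.
Compound 2 `Cc1cc(C(=O)O)ccc1OCCCCOc1ccc(C(=O)C(C)C)c(O)c1C` gives 234 nM in this assay.

Compound 1 stands lowest of these two numbers; its nearest neighbour is compound 2, reached by a 2.1-fold higher number from compound 1 to compound 2 (0.32 log units; beyond the scatter), the change being methyl in place of methoxy on an aromatic carbon. Compound 3 `COc1cc(C(=O)O)ccc1OCCCCOc1ccc(C(=O)CC(C)(C)C)c(O)c1C` differs from compound 1 at another place: neopentyl in place of isopropyl on a carbonyl carbon. Within the data shown here, no measured step touches a carbonyl substituent, so the step between compound 1 and compound 2 does not bear on this change, and no shift beyond the scatter is expected in this assay, in either direction. Compound 3 is therefore estimated at 130 nM, with a range from 45 nM to 400 nM, meaning an expected step of a 1.2-fold higher number from compound 1 to compound 3 (0.06 log units; within the scatter).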

Compound 3, half-maximal effective concentration: 47 nM
Beside the measured number, compound 3's estimate is 2.8-fold (0.44 log units) above it; the measured number falls inside the stated range.
By their numbers in this assay, from the lowest: compound 3; then compound 1; then compound 2.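

At the carbonyl carbon, where compounds 1 and 2 share isopropyl, the change to neopentyl gives a 2.4-fold lower number from compound 1 to compound 3 (0.38 log units; beyond the scatter) in this assay and so shows that this position is not indifferent to the group it carries. The step is modest, and nothing measured here explains it.

Among these compounds, with only two groups compared at this carbon, it stays open whether a longer chain such as n-hexyl, a cyclohexyl ring or an amine would lower the number further. From the compounds shown here alone, whether the neopentyl step holds with methyl in place of methoxy also remains open.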